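Shortening the Acyl Chain: Vinyl Replaces Pent-1-en-1-yl

The source may hold more compounds than are shown below. What is called first, only, known or untested is meant among the compounds shown, and "the series" means these compounds.

Compound 3 `CCC/C=C/C(=O)N(Cc1ccc(OC)c(O)c1)c1cc(OC)c(OC)c(OC)c1` gives 70 nM in a functional assay on MGC-803 cells (Homo sapiens) for inhibition, read by MTT assay, with a stated time of 48 h (a lower number here means a stronger inhibitor, a higher number a weaker inhibitor), the lowest of the three numbers shown. Compound 1 `COc1ccc(CN(C(C)=O)c2cc(OC)c(OC)c(OC)c2)cc1O` lies nearest, at 79 nM, a gap within the scatter; compound 2 `C=C(C)C(=O)N(Cc1ccc(OC)c(O)c1)c1cc(OC)c(OC)c(OC)c1` lies furthest, at 390 nM. Compound 4 `C=CC(=O)N(Cc1ccc(OC)c(O)c1)c1cc(OC)c(OC)c(OC)c1` differs from compound 3 at one point: vinyl in place of pent-1-en-1-yl on a carbonyl carbon. Going by the values given here, two steps bear on this. Lengthening methyl to pent-1-en-1-yl gave a 1.1-fold lower number from compound 1 to compound 3 (0.05 log units; within the scatter), while the branched 1-methylethenyl gave a 4.9-fold higher number from compound 1 to compound 2 (0.69 log units; beyond the scatter) and a 5.6-fold lower number from compound 2 to compound 3 (0.75 log units; beyond the scatter). Vinyl, unbranched and shorter than pent-1-en-1-yl, is therefore expected to change the number little, if at all, beyond the scatter, as a 1.4-fold higher number from compound 3 to compound 4 (0.15 log units; within the scatter). Compound 4 is expected to give about 100 nM in this assay, estimated between 40 nM and 300 nM.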

Compound 4, half-maximal inhibitory concentration: 62 nM
Beside the measured number, compound 4's estimate is 1.6-fold (0.21 log units) above it, and the stated range covers the measured number.
By their numbers in this assay, from the lowest: compounds 4, 3 and 1 (each within the scatter of the next); then compound 2.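

In this assay the carbonyl carbon bound to the amide-type nitrogen accepts vinyl as readily as methyl or pent-1-en-1-yl: a 1.1-fold lower number from compound 3 to compound 4 (0.05 log units; within the scatter) and a 1.3-fold lower number from compound 1 to compound 4 (0.11 log units; within the scatter) leave these three compounds unseparated. Going by these compounds alone, the only step here beyond the scatter, a 6.3-fold lower number from compound 2 to compound 4 (0.80 log units; beyond the scatter) for hydrogen in place of methyl on a double-bonded chain carbon bound to a carbonyl carbon, singles out the branched 1-methylethenyl of compound 2. Nothing shown accounts for this difference. The compounds shown leave open whether a saturated ethyl chain, or a chain ending in an amine or a carboxylic acid, would fit this pattern.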